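Changing the aryl group and expected permeability

This account rests on a few compounds, and the source may have more. Where it says the series, first, only, none or still open, it means among the compounds named here.

Compound 1, `Cc1oc(-c2c(Cl)cccc2Br)nc1CN1CCC(C(=O)NCCCN2C[C@H](C)C[C@H](C)C2)CC1`: "not determined" (no result reported) in a physicochemical assay for permeability, using PAMPA; on this read-out higher numbers stand for higher permeability and lower numbers for lower permeability.
Compound 2, `Cc1ccccc1-c1nc(CN2CCC(C(=O)N3CCN(C4CCN(C)CC4)CC3)CC2)c(C)o1`: a limit of this assay, < 3.2 10^-6 cm/s.

Within the data shown here, compound 1 stands at no number in this assay; the only other value shown is a limit, as the limit of < 3.2 10^-6 cm/s in this assay, at which 1 of the 2 values shown sits, records. Compound 3, `COc1cccc(C)c1-c1nc(CN2CCC(C(=O)NCCCN3C[C@H](C)C[C@H](C)C3)CC2)c(C)o1`, differs from compound 1 in one place: 2-methoxy-6-methylphenyl in place of 2-bromo-6-chlorophenyl on an aromatic carbon. Among the measured compounds shown here, no measured step links these two compounds, so the size and direction of the change in this assay cannot be read from the data, and it may be none beyond the scatter. Compound 3 is therefore expected to give about 2 10^-6 cm/s, estimated between 0.5 10^-6 cm/s and 8 10^-6 cm/s.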

Compound 3, apparent permeability: 198 10^-6 cm/s
Beside the measured number, compound 3's estimate is 99-fold (2.00 log units) below it; measured number outside the range, above it.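

No step between compound 1 and compound 3 can be read in this assay, and nothing shown bears on the value of compound 3.
The compounds shown leave open how far exchanging 2-bromo-6-chlorophenyl for 2-methoxy-6-methylphenyl alone shifts this read-out.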